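The compounds below may be only part of what the source reports. "The series", "measured", "known", "first", "only" and "open" are said of these compounds alone.

Measured so far in a functional assay on MIA PaCa-2 cells (Homo sapiens) for cytotoxicity, read by MTT assay, with a stated time of 72 h; on this read-out higher numbers stand for weaker inhibition and lower numbers for stronger inhibition:
compound 1, `COc1cc(NC2=CC(=O)c3ncncc3C2=O)cc(OC)c1OC`, gives 1500 nM
compound 2, `CC(=O)c1cccc(NC2=CC(=O)c3ncncc3C2=O)c1`, gives 2300 nM
compound 3, `NC(=O)c1ccc(NC2=CC(=O)c3ncncc3C2=O)cc1`, gives 8000 nM

Compound 2 stands second highest of these three numbers. Its nearest neighbour is compound 1, whose number is lower by an amount within the usual scatter, so no order can be read between them. Compound 3 sits furthest away, with a higher number that lies beyond the scatter. The step to compound 4, `COc1cccc(NC2=CC(=O)c3ncncc3C2=O)c1`, changes one group: methoxy in place of acetyl on an aromatic carbon. For the measured compounds named here, no measured pair shows this exchange, so its size cannot be read from the data. In this assay a small step is expected, if any beyond the scatter, with the number more likely to fall than to rise. Compound 4 is expected to give 2000 nM, within 800 nM to 5000 nM. That amounts to an expected step of a 1.2-fold lower number from compound 2 to compound 4 (0.06 log units; within the scatter).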

Compound 4, half-maximal inhibitory concentration: 1800 nM
The estimate for compound 4 lay 1.1-fold (0.05 log units) above the measured number; low and high end bracket the measured number.
By their numbers in this assay, from the lowest: compounds 1, 4 and 2 (each within the scatter of the next); then compound 3.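

Putting methoxy in place of acetyl on this aromatic carbon, meta to a large group, gives a 1.3-fold lower number from compound 2 to compound 4 (0.11 log units; within the scatter) in this assay, so compound 2 and compound 4 cannot be told apart. At this position, then, the assay does not separate these two groups. The data offer no independent measurement that could explain this result. Still open, from the compounds shown here alone, is whether an amine or a carboxylic acid on the same carbon would also leave the number within the scatter. A longer chain such as ethoxy is equally untested here.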